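The source may report more compounds than this note shows. Statements on the series, on what has been measured and on what is new or still open speak of the compounds shown alone.

Compound 3 `O=C(CCCCCCc1ccccc1)c1ncc(-c2cncnc2)o1` stands at the top of the three numbers in an assay (Rattus norvegicus) for inhibition of Fatty-acid amide hydrolase 1 (Homo sapiens) (a higher number here means a weaker inhibitor, a lower number a stronger inhibitor), giving 22 nM. Compound 2 `O=C(CCCCCCc1ccccc1)c1ncc(-c2ccncn2)o1` gives 2.3 nM, and compound 1 `NC(=O)c1cccc(-c2cnc(C(=O)CCCCCCc3ccccc3)o2)n1` gives 1 nM. Compound 4 `CN1CCN(C(=O)c2cnc(C(=O)CCCCCCc3ccccc3)o2)CC1` keeps the shared core but carries (4-methylpiperazin-1-yl)carbonyl in place of pyrimidin-5-yl on an aromatic carbon. The measured steps show that this position sets the strength: a 9.6-fold higher number from compound 2 to compound 3 (0.98 log units; beyond the scatter), and a 22-fold higher number from compound 1 to compound 3 (1.34 log units; beyond the scatter), while a 2.3-fold higher number from compound 1 to compound 2 (0.36 log units; beyond the scatter). Within the data shown here, no measured step swaps an aromatic ring for a non-aromatic carbonyl-linked group at this position, so the direction is uncertain. Compound 1, whose ring substituent also carries a carbonyl, is the strongest in this assay with 1 nM. On that loose kinship, compound 4 is expected to show a 1.5-fold lower number from compound 3 to compound 4 (0.17 log units; within the scatter). The estimate for compound 4 is 15 nM, ranging from 3 nM to 100 nM.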

Compound 4, inhibition constant: 80 nM
Compound 4: middle estimate off by 5.3-fold (0.73 log units), on the low side; the measured number falls inside the stated range.
By their numbers in this assay, from the lowest: compound 1; then compound 2; then compound 3; then compound 4.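

In this assay compound 4, the only one here with a non-aromatic, carbonyl-linked group on this aromatic carbon, is the weakest of the four (with a 3.6-fold higher number from compound 3 to compound 4 (0.56 log units; beyond the scatter) and a 35-fold higher number from compound 2 to compound 4 (1.54 log units; beyond the scatter) and an 80-fold higher number from compound 1 to compound 4 (1.90 log units; beyond the scatter)). So at this position, each of the three aromatic rings shown gives a stronger inhibitor than (4-methylpiperazin-1-yl)carbonyl, though that group still leaves measurable inhibition. No measured evidence here explains the weakening.
These compounds cannot separate the carbonyl link from the piperazine ring. A simple primary amide or a carboxylic acid on this carbon would help to tell these two parts apart.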